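The source may hold more compounds than are shown below. What is called first, only, known or untested is meant among the compounds shown, and "the series" means these compounds.

Measured compounds:
compound 1 `Cc1ccc(-c2cn(/N=C/c3cc4cc(C)ccc4nc3Cl)c(N)n2)cc1`, 22300 nM;
compound 2 `COc1ccc(-c2cn(/N=C/c3cc4cc(C)ccc4nc3Cl)c(N)n2)cc1`, 23600 nM;
compound 3 `Cc1ccc2nc(Cl)c(/C=N/n3cc(-c4ccc(Br)cc4)nc3N)cc2c1`, 38200 nM.

All three share one core and differ only in the group on the aromatic carbon of the five-membered ring. In a functional assay on MDA-MB-231 cells (Homo sapiens) for cytotoxicity, read by MTT assay, with a stated time of 48 h (on this read-out higher numbers stand for weaker inhibition and lower numbers for stronger inhibition), compound 1 gives 22300 nM and compound 2 gives 23600 nM; the step of a 1.1-fold higher number from compound 1 to compound 2 (0.02 log units; within the scatter) is within the scatter. Compound 3 carries the 4-bromophenyl and gives 38200 nM; the steps of a 1.7-fold higher number from compound 1 to compound 3 (0.23 log units; within the scatter) and a 1.6-fold higher number from compound 2 to compound 3 (0.21 log units; within the scatter) are both within the scatter, so compound 3 is not separated from the other two on these numbers.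

Compound 4 `Cc1ccc2nc(Cl)c(/C=N/n3cc(-c4cccc5ccccc45)nc3N)cc2c1` differs from compound 3 by naphthalen-1-yl in place of 4-bromophenyl on an aromatic carbon. The three measured steps all swap one group on the same carbon and none moved the number beyond the scatter; none of them replaces a single aromatic ring by a fused pair of rings, so the new change is only loosely covered. The expectation for this assay is a step of a 1.1-fold lower number from compound 3 to compound 4 (0.04 log units; within the scatter), not beyond the scatter. Compound 4 is therefore estimated at 35000 nM, with a range from 15000 nM to 85000 nM.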

Compound 4, half-maximal inhibitory concentration: > 50000 nM
Compound 4: no number, only a limit; the forecaster's own chance of this, stated with the estimate: 15%; middle value at least 1.4-fold (0.15 log units) away from the limit.
By their numbers in this assay, from the lowest: compounds 1, 2 and 3 (each within the scatter of the next). At a limit, above all of these: compound 4.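

Compound 4 stands at a limit of the assay, not at a number, in this assay: the limit of > 50000 nM in this assay, at which 1 of the 4 values shown sits. Naphthalen-1-yl is the first change on this carbon to pass the scatter, with an at least 2.1-fold higher number from compound 2 to compound 4 (0.32 log units; beyond the scatter) and an at least 2.2-fold higher number from compound 1 to compound 4 (0.35 log units; beyond the scatter), whereas an at least 1.3-fold higher number from compound 3 to compound 4 (0.11 log units; that floor lies within the scatter) leaves compound 3 and compound 4 unseparated. The three groups with a single aromatic ring could not be told apart, so the fused pair of rings gives the first sign that this carbon responds to its group, in the direction of weaker inhibition against compound 1 and compound 2 only.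

On these data alone, the true size of all three steps stays open, since compound 4 has no number. Also open, as far as these compounds go, is how an amine, a carboxylic acid or a longer chain would read on this carbon.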